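Methyl for Hydrogen: An Expected Gain in Receptor Affinity

The compounds below may be only part of what the source reports. "The series", "measured", "known", "first", "only" and "open" are said of these compounds alone.

Compound 1 `O=C(Nc1cccc(Cl)c1)c1cccc2oc(=O)[nH]c12` — 68 nM
Compound 2 `O=C(Nc1cccc(Cl)c1)c1cccc2nn[nH]c12` — > 10000 nM (a limit)
Compound 3 `O=C(Nc1ccccc1)c1cccc2oc(=O)[nH]c12` — 2200 nM

In an assay on isolated protein for binding affinity to metabotropic glutamate receptor 5 (Homo sapiens) (a higher number here means a weaker inhibitor, a lower number a stronger inhibitor), compound 1 gives 68 nM. Compound 3 gives 2200 nM in this assay, the higher of the two numbers reported. Compound 2 sits at the limit of > 10000 nM in this assay, at which 1 of the 3 values shown sits, so its value > 10000 nM is a limit rather than a number. Among the measured compounds shown here, the one measured step, a 32-fold higher number from compound 1 to compound 3 (1.51 log units; beyond the scatter), shows that the group on the aniline ring matters a great deal for binding in this assay.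

Compound 4 `Cc1cccc(NC(=O)c2cccc3oc(=O)[nH]c23)c1` differs from compound 3 by methyl in place of hydrogen on an aromatic carbon. For the measured compounds named here, the step that bears on this change is the one from compound 1 to compound 3, where the same position was emptied of chloro with a large loss. Filling it again with methyl is expected to reverse a good part of that loss in this assay, a large step toward a lower number. Compound 4 is therefore expected to give 150 nM, in the range 40 nM to 600 nM. The expected step is a 15-fold lower number from compound 3 to compound 4 (1.17 log units; beyond the scatter).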

Compound 4, inhibition constant: 109 nM
Compound 4: middle estimate off by 1.4-fold (0.14 log units), on the high side; measured number inside the range.
By their numbers in this assay, from the lowest: compounds 1 and 4 (each within the scatter of the next); then compound 3. At a limit, above all of these: compound 2.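

With methyl in place of hydrogen, this assay shows a 20-fold lower number from compound 3 to compound 4 (1.30 log units; beyond the scatter), so the earlier loss on removing chloro was not a matter of chloro alone: a group holding no halogen atom also restores the low number at this position. Methyl in place of chloro gives a 1.6-fold higher number from compound 1 to compound 4 (0.20 log units; within the scatter) in this assay, so the two groups cannot be told apart here, and the position accepts either of them. Nothing measured among these compounds tells why this position responds as it does.

The compounds shown leave open whether methoxy, trifluoromethyl or an amine at this position would keep binding at this level. They also leave open whether a longer chain such as ethyl would be accepted there, or whether methyl would serve as well elsewhere on the same aromatic ring.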